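The source may report more compounds than this note shows. Statements on the series, on what has been measured and on what is new or still open speak of the compounds shown alone.

Compound 1 `CN(C)CC[C@H](CSc1ccccc1)Nc1ccc(S(=O)(=O)NC(=O)c2ccc(N3CCN(Cc4ccccc4-c4ccc(Cl)cc4)CC3)cc2)cc1C(F)(F)F`: < 1 nM
Compound 2 `Cc1cc(S(=O)(=O)NC(=O)c2ccc(N3CCN(Cc4ccccc4-c4ccc(Cl)cc4)CC3)cc2)ccc1N[C@H](CCN(C)C)CSc1ccccc1`: < 1 nM

In an assay on isolated protein for displacement of a labelled ligand from Bcl2-associated agonist of cell death (Homo sapiens), read by fluorescence polarization (a higher number here means a weaker inhibitor, a lower number a stronger inhibitor), compound 1 gives < 1 nM, which is a limit of the assay rather than a number. Compound 2 gives < 1 nM, likewise only a limit. So compound 2 stands at the limit, and the step that the two limits leave unreadable from compound 1 to compound 2 cannot be sized because of the limit of < 1 nM in this assay, at which 2 of the 2 values shown sit.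

Compound 3 `CN(C)CC[C@H](CSc1ccccc1)Nc1ccc(S(=O)(=O)NC(=O)c2ccc(N3CCN(Cc4ccccc4-c4ccc(Cl)cc4)CC3)cc2)cc1S(C)(=O)=O` differs from compound 2 in methylsulfonyl in place of methyl on an aromatic carbon. Going by the values given here, the only measured step, from compound 1 to compound 2, is unreadable, so no direction can be drawn from it. The step is therefore expected as a step that the limit leaves unreadable from compound 2 to compound 3, none beyond the scatter. Compound 3 is estimated at 0.8 nM, between 0.2 nM and 4 nM.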

Compound 3, inhibition constant: < 1 nM
Compound 3 ended at the assay's limit; the forecaster's own chance of this, stated with the estimate: 60%; the middle value does not contradict the limit.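

No step between compound 1, compound 2 and compound 3 can be read in this assay, because each value is only a limit: the limit of < 1 nM in this assay, at which 3 of the 3 values shown sit.

On these data alone, whether trifluoromethyl, methyl and methylsulfonyl on this aromatic carbon differ in strength remains open.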